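A few compounds are considered here, and "the series" means these few. Any claim that something is new, unique, unknown or untested is made for them only; others in the source may bear on it.

Working notes on the series. Three compounds of the shared core have been run in an ADME assay on microsomes from liver (Homo sapiens) for metabolic stability, read by LC-MS, using NADPH, with a stated time of 45 min, tested at 1 uM; on this read-out higher numbers stand for a longer-lived compound and lower numbers for a shorter-lived compound. Compound 1 `Cc1cc(/C=C/C#N)cc(C)c1Oc1cc(Nc2ccc(C#N)cc2)c(N)cc1C(=O)OCCC#N` gives 0.283 h in this assay. Compound 2 `Cc1cc(/C=C/C#N)cc(C)c1Oc1cc(Nc2ccc(C#N)cc2)c(N)cc1C(=O)NCCC(F)F` gives 0.233 h, and compound 3 `CCNC(=O)c1cc(N)c(Nc2ccc(C#N)cc2)cc1Oc1c(C)cc(/C=C/C#N)cc1C` gives 2.32 h. Compound 1 therefore sits close to compound 2, the gap being a 1.2-fold lower number from compound 1 to compound 2 (0.08 log units; within the scatter), and well under compound 3, the gap being an 8.2-fold higher number from compound 1 to compound 3 (0.91 log units; beyond the scatter).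

Compound 4 `CNC(=O)c1cc(N)c(Nc2ccc(C#N)cc2)cc1Oc1c(C)cc(/C=C/C#N)cc1C` is the next step from compound 1: methylamino in place of 2-cyanoethoxy on a carbonyl carbon. The measured step that bears most on it is the one that likewise puts ethylamino in place of 2-cyanoethoxy on the carbonyl carbon, read as an 8.2-fold higher number from compound 1 to compound 3 (0.91 log units; beyond the scatter). The step from compound 2 to compound 3, a 10-fold higher number from compound 2 to compound 3 (1.00 log units; beyond the scatter), shows that the two measured amides do not agree with each other, so the comparison rests on compound 3 alone, whose ethylamino is the nearest relative of methylamino. A step of the same order upward is therefore expected in this assay, and compound 4 is expected to give 2.5 h, between 1 h and 6 h. The expected step from compound 1 to compound 4 is an 8.8-fold higher number from compound 1 to compound 4 (0.95 log units; beyond the scatter).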

Compound 4, half-life: 1.87 h
The estimate for compound 4 lay 1.3-fold (0.13 log units) above the measured number, and the stated range covers the measured number.
By their numbers in this assay, from the lowest: compounds 2 and 1 (each within the scatter of the next); then compounds 4 and 3 (each within the scatter of the next).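

In this assay, methylamino in place of 2-cyanoethoxy on the carbonyl carbon gives a 6.6-fold higher number from compound 1 to compound 4 (0.82 log units; beyond the scatter), so the higher number seen with ethylamino no longer rests on compound 3 alone. Methylamino and ethylamino are not told apart at this position, at a 1.2-fold lower number from compound 3 to compound 4 (0.09 log units; within the scatter), but an amide there does not by itself bring the higher number: compound 2 goes against that pattern, as shown by an 8.0-fold higher number from compound 2 to compound 4 (0.90 log units; beyond the scatter). Nothing available gives a reason for these steps.

The compounds shown do not separate the chain length of compound 2 from its two fluorines, a question that propylamino on the carbonyl carbon would address. On these data alone, how an unsubstituted amino group or a carboxylic acid at this position compares with compound 3 and compound 4 also stays open.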